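The source may report more compounds than this note shows. Statements on the series, on what has been measured and on what is new or still open speak of the compounds shown alone.

Compounds measured in an ADME assay on HepG2 cells (Homo sapiens) for cytotoxicity, read by MTT assay, with a stated time of 48 h; a higher number here means a weaker inhibitor, a lower number a stronger inhibitor:
Compound 1 `O=S(=O)(c1ccc(-c2ccc3ncnc(Nc4ccc(OCc5cccc(F)c5)c(Cl)c4)c3c2)cc1)N1CCSCC1`: > 15000 nM, a limit.
Compound 2 `CS(=O)(=O)c1ccc(-c2ccc3ncnc(Nc4ccc(OCc5cccc(F)c5)c(Cl)c4)c3c2)cc1`: > 15000 nM, a limit.

In this assay compound 2 is known only by a limit, > 15000 nM, and not by a number. The evidence so far amounts to the limit of > 15000 nM in this assay, at which 2 of the 2 values shown sit. Going by the values given here, the one measured step is a step that the two limits leave unreadable from compound 1 to compound 2, so it offers no size to carry forward.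

Compound 3 `CN(C)S(=O)(=O)c1ccccc1-c1ccc2ncnc(Nc3ccc(OCc4cccc(F)c4)c(Cl)c3)c2c1` has not yet been measured. It differs from compound 2 by 2-(dimethylsulfamoyl)phenyl in place of 4-(methylsulfonyl)phenyl on an aromatic carbon of a six-membered aromatic ring of carbon only, with the rest of the structure unchanged.

Among the compounds with values here, no measured step has a readable size, so any expectation here is weak. Since compound 2 stands at the limit > 15000 nM, the expected change in this assay is none beyond the scatter, in neither direction, and a second report of only a limit would be no surprise. The step is therefore expected to be a step that the limit leaves unreadable from compound 2 to compound 3. For compound 3 the estimated value is 20000 nM, with an expected range from 8000 nM to 50000 nM.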

Compound 3, half-maximal inhibitory concentration: > 15000 nM
Compound 3: no number, only a limit (the forecaster's own chance of this, stated with the estimate: 70%); the middle value lies beyond the limit too.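

Compound 2 and compound 3 are both known in this assay only by a limit, so the step between them cannot be read. The compounds shown leave open how far each lies beyond that limit, and so whether either change of group shifts the read-out at all. The evidence stands as follows: the limit of > 15000 nM in this assay, at which 3 of the 3 values shown sit.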